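This account rests on a few compounds, and the source may have more. Where it says the series, first, only, none or still open, it means among the compounds named here.

Measured in a functional assay on HepG2 cells (Homo sapiens) for antiproliferative activity, read by MTT assay, with a stated time of 48 h; a lower number here means a stronger inhibitor of growth, a higher number a weaker inhibitor of growth:
- compound 1 `COC(=O)N1N=C(c2ccccc2)CC1c1ccc(OC)c(O)c1`: 9810 nM
- compound 2 `COC(=O)N1N=C(c2ccccc2)CC1c1ccc(OC)c(OC)c1`: 9150 nM

Compound 2 stands within the scatter of compound 1, so the two cannot be ranked. Compound 3 `COC(=O)N1N=C(c2ccccc2)CC1c1cc(OC)c(OC)cc1OC` adds to compound 2 a methoxy in place of hydrogen on an aromatic carbon. For the measured compounds named here, only one measured step exists, a 1.1-fold lower number from compound 1 to compound 2 (0.03 log units; within the scatter), for methyl in place of hydrogen on an oxygen on an aromatic ring. It is a different change and offers only weak guidance. No step beyond the scatter is therefore expected in this assay, and no direction is favoured. The expected step is a 1.1-fold lower number from compound 2 to compound 3 (0.03 log units; within the scatter). For compound 3 the estimated value is 8500 nM, with an expected range of 3000 nM to 22000 nM.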

Compound 3, concentration for 50% growth inhibition: 6530 nM
The estimate for compound 3 lay 1.3-fold (0.11 log units) above the measured number; the measured number falls inside the stated range.
By their numbers in this assay, from the lowest: compounds 3, 2 and 1 (each within the scatter of the next).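

In this assay, a methoxy placed on the aromatic carbon ortho to a large group, meta to a methoxy group and para to a methoxy group gives a 1.4-fold lower number from compound 2 to compound 3 (0.15 log units; within the scatter) and so leaves the number within the scatter. This position therefore takes the added methoxy without a readable loss or gain in growth inhibition, and the series now holds a second change that produces no step beyond the scatter. No measured property bears on this result.

On these data alone, it remains open whether a different group at this position, such as an amine or a carboxylic acid, would give a step beyond the scatter. Changes to the methyl ester or the unsubstituted phenyl of the shared core also remain open.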